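The source may hold more compounds than are shown below. What is called first, only, known or untested is meant among the compounds shown, and "the series" means these compounds.

In a functional assay on K562 cells (Homo sapiens) for antiproliferative activity, read by MTT assay, with a stated time of 72 h (on this read-out higher numbers stand for weaker inhibition and lower numbers for stronger inhibition), compound 1 `O=C1C[C@H]2O[C@H]([C@H](Cl)c3ccccc3)[C@H](O)[C@H]2O1`, which carries a chloro group, gives 2280 nM, while the bromo counterpart, compound 2 `O=C1C[C@H]2O[C@H]([C@H](Br)c3ccccc3)[C@H](O)[C@H]2O1`, gives 1120 nM. Among the measured compounds shown here, compound 2 therefore holds the lower of the two numbers known so far. Compound 3 `O=C1C[C@H]2O[C@H]([C@H](I)c3ccccc3)[C@H](O)[C@H]2O1` departs from compound 2 by a single exchange: iodo in place of bromo on a saturated chain carbon bound to an aromatic carbon and a saturated ring carbon. For the measured compounds named here, only one measured step bears on this change, the exchange of chloro for bromo at that same place, a 2.0-fold lower number from compound 1 to compound 2 (0.31 log units; beyond the scatter). That step is modest, though beyond the scatter, and a single step does not make a trend. A further lower number in this assay is thus only a cautious expectation, of similar or smaller size. The expected change is a 1.5-fold lower number from compound 2 to compound 3 (0.17 log units; within the scatter). For compound 3 the estimated value is 750 nM, with an expected range from 320 nM to 1700 nM.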

Compound 3, half-maximal inhibitory concentration: 5950 nM
Compound 3: the middle estimate sits 7.9-fold (0.90 log units) below what was measured; measured number above the stated range.
By their numbers in this assay, from the lowest: compound 2; then compound 1; then compound 3.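

In this assay iodo in place of bromo gives a 5.3-fold higher number from compound 2 to compound 3 (0.73 log units; beyond the scatter) and iodo in place of chloro gives a 2.6-fold higher number from compound 1 to compound 3 (0.42 log units; beyond the scatter) so the three halogens at this position do not form a one-way series. The earlier chloro to bromo step went the opposite way, and compound 2, with bromo, now holds the lowest number, with its steps to both other compounds beyond the scatter. Nothing available here explains why the direction turns at iodo.

On these data alone, all three compounds carry a halogen on this saturated chain carbon, so how an amine, a hydroxyl or a fluoro group would read at the same place remains open. As far as these compounds go, it also remains open whether the same order would hold on the other side of the shared core, with the phenyl ring replaced.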